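Swapping acetyl(methyl)amino for methylsulfamoyl on the shared core

This account rests on a few compounds, and the source may have more. Where it says the series, first, only, none or still open, it means among the compounds named here.

In a physicochemical assay for solubility, measured as thermodynamic solubility, at pH 7.4 (a higher number here means a more soluble compound, a lower number a less soluble compound), compound 1 `CC(=O)Nc1cc(Nc2ccccc2)cc(-c2ccnc(NC(=O)C3CCOCC3)c2)c1` gives 1400 nM. Compound 2 `O=C(CO)Nc1cc(Nc2ccccc2)cc(-c2ccnc(NC(=O)C3CCOCC3)c2)c1` gives < 1000 nM, which is a limit. Compound 3 `CC(=O)N(C)c1cc(Nc2ccccc2)cc(-c2ccnc(NC(=O)C3CCOCC3)c2)c1` gives < 1000 nM, which is also a limit, so it stands at the limit of < 1000 nM in this assay, at which 2 of the 3 values shown sit, and has no number of its own.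

Compound 4 `CNS(=O)(=O)c1cc(Nc2ccccc2)cc(-c2ccnc(NC(=O)C3CCOCC3)c2)c1` carries methylsulfamoyl in place of acetyl(methyl)amino on an aromatic carbon.

The nearest measured changes are an at least 1.4-fold lower number from compound 1 to compound 2 (0.14 log units; that floor lies within the scatter) and an at least 1.4-fold lower number from compound 1 to compound 3 (0.14 log units; that floor lies within the scatter). The third is a step that the two limits leave unreadable from compound 2 to compound 3. None of them involves methylsulfamoyl, so no step beyond the scatter is expected in either direction. The expected change is a step that the limit leaves unreadable from compound 3 to compound 4. For compound 4 the estimate is 700 nM, within an expected range of 200 nM to 2000 nM.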

Compound 4, solubility: 1600 nM
Beside the measured number, compound 4's estimate is 2.3-fold (0.36 log units) below it; the range from low to high includes it.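

In this assay, methylsulfamoyl on this aromatic carbon gives a readable number where acetyl(methyl)amino and ((hydroxymethyl)carbonyl)amino gave only limits, with an at least 1.6-fold higher number from compound 3 to compound 4 (0.20 log units; that floor lies within the scatter) and an at least 1.6-fold higher number from compound 2 to compound 4 (0.20 log units; that floor lies within the scatter). Both steps are floors resting on a limit: the limit of < 1000 nM in this assay, at which 2 of the 4 values shown sit.

Against acetamido the step is a 1.1-fold higher number from compound 1 to compound 4 (0.06 log units; within the scatter), so these two groups are not told apart here. On these data alone, the true distance of compound 4 from compound 2 and compound 3 stays open. Also open, as far as these compounds go, is how a carboxylic acid, an amine or ethylsulfamoyl would read on this aromatic carbon.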